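Extending a Chain on Two Related Cores

This account rests on a few compounds, and the source may have more. Where it says the series, first, only, none or still open, it means among the compounds named here.

Four compounds share a long saturated chain that ends in the same small group and carries a charged sulfur near its other end; they differ in what sits beyond that sulfur and in how long the chain is. Compound 1 `[O-][S+](CCCCCN=C=S)Cc1ccccc1` and compound 3 `[O-][S+](CCCCCCN=C=S)Cc1ccccc1` carry one end piece, while compound 2 `CC(C)[S+]([O-])CCCCCN=C=S` and compound 4 `CC(C)[S+]([O-])CCCCCCN=C=S` carry another. The difference between the two cores is not broken down here.

In a functional assay on SH-SY5Y cells (Homo sapiens) for cytotoxicity, read by MTT assay, with a stated time of 72 h (on this read-out lower numbers stand for stronger inhibition and higher numbers for weaker inhibition), compound 1 gives 7010 nM, compound 3 gives 7630 nM and compound 2 gives 8620 nM. The three numbers lie close to one another.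

Compound 3 differs from compound 1 in a single place: a group of 4 heavy atoms (2 carbon, 1 nitrogen, 1 sulfur; no ring) in place of a group of 3 heavy atoms (1 carbon, 1 nitrogen, 1 sulfur; no ring), on a saturated chain carbon, five bonds along the chain from a sulfur The step this produced was a 1.1-fold higher number from compound 1 to compound 3 (0.04 log units; within the scatter), so adding one link to the chain left the outcome essentially where it was.

Compound 4 stands to compound 2 exactly as compound 3 stands to compound 1: a group of 4 heavy atoms (2 carbon, 1 nitrogen, 1 sulfur; no ring) in place of a group of 3 heavy atoms (1 carbon, 1 nitrogen, 1 sulfur; no ring), on a saturated chain carbon, five bonds along the chain from a sulfur Both changes sit at the same place on the chain, so this is the same change made on the other core. Going by the values given here, the only measured instance of it is the one from compound 1 to compound 3, which stayed within the scatter, and a comparably small step is expected here, namely a 1.1-fold higher number from compound 2 to compound 4 (0.03 log units; within the scatter).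

Compound 4 is therefore expected to give about 9300 nM in this assay, because the matching step a 1.1-fold higher number from compound 1 to compound 3 (0.04 log units; within the scatter) was within the scatter, with a likely range from 5500 nM to 16000 nM.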

Compound 4, half-maximal inhibitory concentration: 7820 nM
Estimate against measurement, compound 4: 1.2-fold (0.08 log units) above; the measured number falls inside the stated range.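

Adding one link to the chain on the other core gives a 1.1-fold lower number from compound 2 to compound 4 (0.04 log units; within the scatter) in this assay. Set beside the earlier step, the change carries across the two cores without any difference that this assay can detect: the same change on two cores in this assay, a 1.1-fold higher number (0.04 log units; within the scatter) from compound 1 to compound 3 and a 1.1-fold lower number (0.04 log units; within the scatter) from compound 2 to compound 4, 1.2-fold (0.08 log units) apart, within the scatter of two such steps. In these two pairs, then, the extra link leaves the result within the usual scatter whichever end piece lies beyond the charged sulfur, but steps this small cannot reveal a weak effect of chain length, and two pairs cannot show how the same change would behave on any further core or in any other test.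

What a much shorter or a much longer chain would do remains open, since the compounds shown cover only a narrow range of chain lengths and all give numbers close to one another. Also open, from the compounds shown here alone, is whether the result depends on the small group at the end of the chain, for instance if an amine or a carboxylic acid stood in its place, and whether such a replacement would act alike on both cores.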